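The compounds below may be only part of what the source reports. "The series", "measured", "known", "first", "only" and "open" are said of these compounds alone.

Compound 1 `CCC(=O)NCCCc1cccc2c1C[C@@H](CCCCc1ccccc1)O2`: 20 nM
Compound 2 `O=C(NC[C@@H]1C[C@H]1c1cccc2c1C[C@@H](CCCCc1ccccc1)O2)C1CC1`: 5 nM
Compound 3 `O=C(NCCCc1cccc2c1C[C@@H](CCCCc1ccccc1)O2)C1CC1`: 30 nM

All three share one core and differ only in the side chain and in the group on the carbonyl carbon. In an assay on NIH3T3 cells for binding affinity to melatonin receptor type 1B (Homo sapiens) (a higher number here means a weaker inhibitor, a lower number a stronger inhibitor), compound 3 gives 30 nM; compound 1 lies within the usual scatter of that figure, while compound 2 lies clearly lower, beyond the scatter. Compound 4 `CCNC(=O)NCCCc1cccc2c1C[C@@H](CCCCc1ccccc1)O2` has not yet been measured. It differs from compound 3 in one place: ethylamino in place of cyclopropyl on a carbonyl carbon. Within the data shown here, the only measured step at this position is a 1.5-fold higher number from compound 1 to compound 3 (0.18 log units; within the scatter), and no measured pair tests an ethylamino group here. The estimated step is therefore a 1.2-fold lower number from compound 3 to compound 4 (0.08 log units; within the scatter). In this assay compound 4 is expected at about 25 nM, with a range from 8 nM to 80 nM.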

Compound 4, inhibition constant: 40 nM
Beside the measured number, compound 4's estimate is 1.6-fold (0.20 log units) below it; the measured number falls inside the stated range.
By their numbers in this assay, from the lowest: compound 2; then compounds 1, 3 and 4 (each within the scatter of the next).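

In this assay, ethylamino brings a nitrogen and a hydrogen-bond donor onto the carbonyl carbon, yet the number stays within the scatter of the cyclopropyl compound (a 1.3-fold higher number from compound 3 to compound 4 (0.12 log units; within the scatter)). It also stays within the scatter of the ethyl compound (a 2.0-fold higher number from compound 1 to compound 4 (0.30 log units; within the scatter)), so with this side chain, these three groups cannot be told apart. Nothing available explains this result. On these data alone, whether a longer chain or a phenyl ring on the carbonyl carbon would separate from these three remains open. So does how ethylamino would behave on the side chain of compound 2.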